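The source may hold more compounds than are shown below. What is called first, only, known or untested is meant among the compounds shown, and "the series" means these compounds.

Compound 1, `Nc1n[nH]c2cc(-c3cn([C@@H]4CN[C@H](C(=O)Nc5ccc(Cl)c(C(F)(F)F)c5)C4)nn3)ccc12`, is the reference point of this small set. In a functional assay on K562/Adr cells (Homo sapiens) for inhibition, read by MTT assay, with a stated time of 48 h, tested at 30 uM (on this read-out lower numbers stand for less inhibition and higher numbers for more inhibition at the one concentration tested (going by the name of the read-out)), compound 1 gives 48.2%. Compound 2, `CC(=O)Nc1n[nH]c2cc(-c3cn([C@@H]4CN[C@H](C(=O)Nc5ccc(Cl)c(C(F)(F)F)c5)C4)nn3)ccc12`, carries one change relative to compound 1: acetyl in place of hydrogen on a nitrogen on an aromatic ring. In this assay compound 2 gives 23.4%, and the step is a number 24.8 percentage points lower from compound 1 to compound 2 (beyond the scatter).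

Compound 3, `Nc1nc2ccc(-c3cn([C@@H]4CN[C@H](C(=O)Nc5ccc(Br)cc5)C4)nn3)nc2s1`, is built on a different core; the difference between the two cores is not broken down here. In this assay compound 3 gives 35.9%, which places it between the two earlier compounds, beyond the scatter from each.

Compound 4, `CC(=O)Nc1nc2ccc(-c3cn([C@@H]4CN[C@H](C(=O)Nc5ccc(Br)cc5)C4)nn3)nc2s1`, has not yet been measured. It differs from compound 3 as follows: acetyl in place of hydrogen on a nitrogen on an aromatic ring. This is the same change that was made from compound 1 to compound 2, and it occurs twice among the four compounds; the place of the change reads identically in both cases, so it is treated as the same change rather than merely the same kind. The expected outcome rests on a single precedent, the step of a number 24.8 percentage points lower from compound 1 to compound 2 (beyond the scatter), so the estimate carries considerable uncertainty. For compound 4 in this assay the expected step is a number 21.9 percentage points lower from compound 3 to compound 4 (beyond the scatter), with a loss of inhibition of roughly the same size anticipated. The estimate for compound 4 is therefore 14%, with a range from 0% to 30%.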

Compound 4, a percentage reported as inhibition, at one concentration (the size of the read-out at that concentration, not a potency): 32%
Compound 4: the middle estimate sits 18 percentage points below what was measured, and the stated range ends below it.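

On the core of compound 3, going from amino to acetamido gives a number 3.9 percentage points lower from compound 3 to compound 4 (within the scatter) in this assay, so the loss seen on the core of compound 1 does not recur here. The two steps therefore cannot be treated as one transferable effect of this change in this series: the same change on two cores in this assay, a number 24.8 percentage points lower (beyond the scatter) from compound 1 to compound 2 and a number 3.9 percentage points lower (within the scatter) from compound 3 to compound 4, 20.9 percentage points apart, beyond the scatter of two such steps. This does not show what sets the two steps apart, since the two pairs differ both in the core and in the substituents on the aromatic ring of the amide, and two pairs give no rule for how the change would behave on any further core.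

The compounds shown leave open whether the core or the amide ring governs the size of the step, which a pair combining the core of compound 1 with the bromophenyl amide of compound 3 could help to separate. They also leave open whether a longer acyl chain such as butanoyl, or a methanesulfonyl group, on the same nitrogen would follow the acetyl group on either core.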